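Adding a chloro group to compound 1: what cell toxicity to expect

This account rests on a few compounds, and the source may have more. Where it says the series, first, only, none or still open, it means among the compounds named here.

Compound 1 `N#Cc1cc2c(Oc3ccc(F)cc3OCCn3ccc(=O)[nH]c3=O)cccn2c1` is the starting point. In an ADME assay on MT2 cells (Homo sapiens) for cytotoxicity, read by MTT assay (on this read-out higher numbers stand for lower toxicity in this test and lower numbers for higher toxicity in this test), compound 1 gives 100000 nM. Going by the values given here, this is the only outright number among the three results in hand, as the other two results are limits of the assay rather than numbers. Compound 2 `N#Cc1cc2c(Oc3ccccc3OCCn3ccc(=O)[nH]c3=O)cccn2c1` carries a hydrogen where compound 1 carries fluoro, and in this assay compound 2 reaches only a limit, > 100000 nM. Compound 3 `N#Cc1ccc2c(Oc3ccccc3OCCn3ccc(=O)[nH]c3=O)cc(F)cc2c1` likewise reaches only a limit in this assay, > 100000 nM. Among the compounds with values here, the single step that can be read is a number no lower from compound 1 to compound 2 (the limit leaves the size open), and its size stays open because of the limit of > 100000 nM in this assay, at which 2 of the 3 values shown sit.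

Compound 4 `N#Cc1cc2c(Oc3ccc(F)cc3OCCn3ccc(=O)[nH]c3=O)cc(Cl)cn2c1` differs from compound 1 in one place: chloro in place of hydrogen on an aromatic carbon. Within the data shown here, no measured step swaps a chloro for a hydrogen, so no step bears directly on this change. All three measured results, however, sit at or at the edge of the same ceiling, and a value near that ceiling is therefore the expectation for compound 4 as well, with an even chance that only a limit is reported. Compound 4 is expected to give about 100000 nM, somewhere between 40000 nM and 100000 nM. The step this estimate means, no change at the digits printed from compound 1 to compound 4 (within the scatter), is expected to lie within the usual scatter.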

Compound 4, half-maximal cytotoxic concentration: 15000 nM
For compound 4 the middle estimate is 6.7-fold (0.82 log units) above the measured one; the measured number lies below the stated range.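

In this assay, putting chloro in place of hydrogen gives a 6.7-fold lower number from compound 1 to compound 4 (0.82 log units; beyond the scatter), so this aromatic carbon, two atoms from the ring nitrogen, is not a silent spot on the core: one added chlorine atom is enough to change the read-out. Since a lower number here stands for higher toxicity in this test, compound 4 shows that a single change to the core of compound 1 can bring out toxicity in these cells, and the size of that change can be read. The only earlier step, the swap of fluoro for hydrogen, could not be sized in this way because the value of compound 2 is a limit and not a number: the limit of > 100000 nM in this assay, at which 2 of the 4 values shown sit.

The compounds shown leave open whether this shift belongs to chloro alone or would come with any group on this carbon, such as a methyl, a methoxy or an amine. They also leave open whether chloro at this place would have the same effect on compound 2, which carries hydrogen where compound 1 carries fluoro.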